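This account rests on a few compounds, and the source may have more. Where it says the series, first, only, none or still open, it means among the compounds named here.

Measured compounds in a functional assay on A549 cells (Homo sapiens) for inhibition, read by sulforhodamine B assay, with a stated time of 48 h; on this read-out higher numbers stand for weaker inhibition of growth and lower numbers for stronger inhibition of growth: compound 1 `COC(=O)[C@@]1(C)CCC=C2[C@@H]1CC[C@@H](C)[C@]2(C)Cc1c[nH]c2ccc(C(F)(F)F)cc12` gives 15000 nM; compound 2 `COC(=O)[C@@]1(C)CCC=C2[C@@H]1CC[C@@H](C)[C@]2(C)Cc1c(C)[nH]c2ccc(Cl)cc12` gives 17000 nM; compound 3 `COC(=O)[C@@]1(C)CCC=C2[C@@H]1CC[C@@H](C)[C@]2(C)Cc1c(C)[nH]c2ccc(F)cc12` gives 15000 nM.

Compound 3 stands level with compound 1 at the digits shown, the two together the lowest of the three numbers, and compound 2 sits within the scatter of both. Compound 4 `COC(=O)[C@@]1(C)CCC=C2[C@@H]1CC[C@@H](C)[C@]2(C)Cc1c(C)[nH]c2ccc(C(F)(F)F)cc12` differs from compound 3 by trifluoromethyl in place of fluoro on an aromatic carbon. For the measured compounds named here, the only measured step at this position, a 1.1-fold lower number from compound 2 to compound 3 (0.05 log units; within the scatter), lies within the scatter. Compound 1 already carries trifluoromethyl at this place and gives 15000 nM, no different from compound 3. The step of no change at the digits printed from compound 3 to compound 4 (within the scatter) is therefore expected to stay within the scatter. Compound 4 is estimated at 15000 nM, range 7500 nM to 30000 nM.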

Compound 4, concentration for 50% growth inhibition: 17000 nM
For compound 4 the middle estimate is 1.1-fold (0.05 log units) below the measured one; measured number inside the range.
By their numbers in this assay, from the lowest: compounds 1, 3, 2 and 4 (each within the scatter of the next).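

On the aromatic carbon, with the methyl in place, trifluoromethyl now reads directly against both halogens (a 1.1-fold higher number from compound 3 to compound 4 (0.05 log units; within the scatter); no change at the digits printed from compound 2 to compound 4 (within the scatter)), and neither step separates the groups. For the compounds shown here, the methyl is also tested here for the first time with trifluoromethyl held fixed, and it too stays within the scatter (a 1.1-fold higher number from compound 1 to compound 4 (0.05 log units; within the scatter)). No measurement bears on why these steps are so small.

Going by these compounds, whether an amine or a carboxylic acid on this aromatic carbon would move the number beyond the scatter remains open. So does the effect of a longer chain in place of the methyl.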